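The compounds below may be only part of what the source reports. "The series", "measured", "known", "first", "only" and "open" are said of these compounds alone.

Compound 1 `COc1ccc(Oc2ccc(C(C)C)cc2-c2ccsc2S(=O)(=O)NCCNC(=O)Nc2cc(Cl)cc(Cl)c2)cc1OC` serves as the starting point. In a functional assay on HeLa cells (Homo sapiens) for inhibition, read by CCK-8 assay, with a stated time of 48 h (on this read-out lower numbers stand for stronger inhibition and higher numbers for weaker inhibition), compound 1 gives 11600 nM. Compound 2 `CC(C)c1ccc(Oc2ccc(O)c(O)c2)c(-c2ccsc2S(=O)(=O)NCCNC(=O)Nc2cc(Cl)cc(Cl)c2)c1` has the same core and differs from compound 1 only by 3,4-dihydroxyphenyl in place of 3,4-dimethoxyphenyl on an oxygen on an aromatic ring. For compound 2 this assay reports only a limit, > 50000 nM. The change thus produced an at least 4.3-fold higher number from compound 1 to compound 2 (0.63 log units; beyond the scatter), and since that step runs into the limit of > 50000 nM in this assay, at which 1 of the 3 values shown sits, its true size may be larger than counted.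

Compound 3 `COc1ccc(Oc2ccc(C(C)C)cc2-c2ccsc2S(=O)(=O)NCCNC(=S)Nc2cc(C(F)(F)F)cc(C(F)(F)F)c2)cc1OC` has a core that differs from compound 1 in several respects; the difference between the two cores is not broken down here. In this assay compound 3 gives 8300 nM, which lies within the scatter of the value of compound 1.

Compound 4 `CC(C)c1ccc(Oc2ccc(O)c(O)c2)c(-c2ccsc2S(=O)(=O)NCCNC(=S)Nc2cc(C(F)(F)F)cc(C(F)(F)F)c2)c1` stands to compound 3 as compound 2 stands to compound 1: it carries 3,4-dihydroxyphenyl in place of 3,4-dimethoxyphenyl on an oxygen on an aromatic ring, the same change at the same kind of place. From compound 3 to compound 4 a step of about a 6.0-fold higher number from compound 3 to compound 4 (0.78 log units; beyond the scatter) is expected, since the identical change gave an at least 4.3-fold higher number from compound 1 to compound 2 (0.63 log units; beyond the scatter) on a starting point of similar strength. Compound 4 is therefore expected to give roughly 50000 nM, somewhere between 25000 nM and 120000 nM, with a real chance that this assay returns only a limit.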

Compound 4, half-maximal inhibitory concentration: > 20000 nM
Compound 4 ended at the assay's limit; the forecaster's own chance of this, stated with the estimate: 60%; the middle value lies beyond the limit too.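

In this assay, putting 3,4-dihydroxyphenyl in place of 3,4-dimethoxyphenyl on the second core again raised the number, giving an at least 2.4-fold higher number from compound 3 to compound 4 (0.38 log units; beyond the scatter). Compound 4 gives > 20000 nM, which is a limit of the assay and not a number. The change therefore pointed the same way on both cores shown, towards weaker inhibition, but this rests on only two pairs and does not establish that its size carries over: the same change on two cores in this assay, an at least 4.3-fold higher number (0.63 log units; beyond the scatter) from compound 1 to compound 2 and an at least 2.4-fold higher number (0.38 log units; beyond the scatter) from compound 3 to compound 4; the limit leaves it open whether they differ.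

The compounds shown leave open how the ring would read with other groups on it, such as a single hydroxyl group paired with a single methoxy group, or a carboxylic acid in place of the two hydroxyl groups. They also leave open whether the same direction would hold on cores beyond these two, and how large the step really is once both members of a pair give numbers rather than limits.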